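Swapping a methyl for a benzamido group

The source may report more compounds than this note shows. Statements on the series, on what has been measured and on what is new or still open speak of the compounds shown alone.

- Compound 1 `COc1ccccc1CN1CCC=C(CCC(=O)NO)C1=O`: > 10000 nM (a limit of the assay, not a number)
- Compound 2 `Cc1ccc(CN2CCC=C(CCC(=O)NO)C2=O)cc1`: 8510 nM
- Compound 3 `Cc1cccc(CN2CCC=C(CCC(=O)NO)C2=O)c1`: > 10000 nM (a limit of the assay, not a number)
- Compound 4 `O=C(CCC1=CCCN(Cc2ccc(NC(=O)c3ccccc3)cc2)C1=O)NO`: not yet measured

Within the data shown here, in a functional assay on HCT-15 cells (Homo sapiens) for inhibition, read by sulforhodamine B assay (a lower number here means a stronger inhibitor of growth, a higher number a weaker inhibitor of growth), compound 2 gives 8510 nM, the only true number among the three results. The other two results mark (the limit of > 10000 nM in this assay, at which 2 of the 3 values shown sit).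

Compound 4 keeps the core of compound 2 but carries benzamido in place of methyl on an aromatic carbon, para to a large group: benzamido in place of methyl on an aromatic carbon.

Among the measured compounds shown here, only one measured step bears on this change. It is an at least 1.1-fold higher number from compound 2 to compound 3 (0.07 log units; that floor lies within the scatter), where 3-methylphenyl replaces 4-methylphenyl. That step ends at a limit, and it involves no group resembling benzamido, so it gives little guide to size.

Compound 2 stands at 8510 nM. Little room remains up to the limit of > 10000 nM in this assay, at which 2 of the 3 values shown sit, so any change that can be read as a number must run towards a lower value. A modest move in that direction is expected, although a result at the limit remains possible. The expected change is a 2.4-fold lower number from compound 2 to compound 4 (0.39 log units; beyond the scatter). For compound 4 the estimated value is 3500 nM, with an expected range of 900 nM to 10000 nM.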

Compound 4, concentration for 50% growth inhibition: > 10000 nM
Compound 4: no number, only a limit (the forecaster's own chance of this, stated with the estimate: 30%); middle value at least 2.8-fold (0.45 log units) from the limit.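

In this assay compound 4 gives > 10000 nM, a limit of the assay and not a number. Benzamido in place of methyl on an aromatic carbon, para to a large group, reads as an at least 1.1-fold higher number from compound 2 to compound 4 (0.07 log units; that floor lies within the scatter), so adding this much larger group, with its extra six-membered aromatic ring, gives no measurable gain in growth inhibition, and how much weaker compound 4 may be cannot be told. The earlier compounds carried only small groups on this aromatic ring, whereas this result extends the limit to a far larger one and leaves compound 2 as the only compound with a true number: the limit of > 10000 nM in this assay, at which 3 of the 4 values shown sit.

The compounds shown leave open whether a different group at this place, such as an amine or a carboxylic acid, would bring the number clearly down. They also leave open whether a longer chain between the amide-type nitrogen in the ring and the aromatic ring would do so, and the steps ending at the limit cannot be read for size.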